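A hydroxy group takes the place of nitro

The source may hold more compounds than are shown below. What is called first, only, known or untested is meant among the compounds shown, and "the series" means these compounds.

Values so far in a functional assay on NCI-H460 cells (Homo sapiens) for cytotoxicity, read by MTT assay, with a stated time of 48 h; a lower number here means a stronger inhibitor, a higher number a weaker inhibitor
Compound 1 `COc1cc(/C=C/C(=O)/C=C/c2nc3ccccc3n2C)ccc1O` gives 7000 nM
Compound 2 `COc1ccc2c(c1)nc(/C=C/C(=O)/C=C/c1ccc(O)c(OC)c1)n2C` gives 12700 nM
Compound 3 `COc1cc(/C=C/C(=O)/C=C/c2nc3cc([N+](=O)[O-])ccc3n2C)ccc1O` gives 6700 nM

Compound 3 cannot be ranked against the other two. The measured 1.0-fold lower number from compound 1 to compound 3 (0.02 log units; within the scatter) and the measured 1.9-fold lower number from compound 2 to compound 3 (0.28 log units; within the scatter) both lie within the scatter of repeated measurements, so the three values count as alike in this assay for now.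

The next compound is compound 4 `COc1cc(/C=C/C(=O)/C=C/c2nc3cc(O)ccc3n2C)ccc1O`, which keeps the shared core of compound 3 and carries hydroxy in place of nitro on an aromatic carbon. Within the data shown here, the counted difference is hydroxy in place of nitro on an aromatic carbon and it is the only change.

Among the measured compounds shown here, three measured steps bear on this. Each one swaps a group on an aromatic carbon. Nitro in place of hydrogen gave a 1.0-fold lower number from compound 1 to compound 3 (0.02 log units; within the scatter) and nitro in place of methoxy gave a 1.9-fold lower number from compound 2 to compound 3 (0.28 log units; within the scatter) while methoxy in place of hydrogen gave a 1.8-fold higher number from compound 1 to compound 2 (0.26 log units; within the scatter) and none of the three goes beyond the scatter. For the measured compounds named here, no measured compound carries hydroxy at this spot, so this is an extrapolation and the direction stays open.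

No step beyond the scatter is expected, and the estimated size is a 1.2-fold higher number from compound 3 to compound 4 (0.08 log units; within the scatter) at most a small one. The estimate for compound 4 is 8000 nM with an expected range from 3000 nM to 20000 nM in this test.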

Compound 4, half-maximal inhibitory concentration: 7600 nM
Compound 4: the middle estimate sits 1.1-fold (0.02 log units) above what was measured; the measured number falls inside the stated range.
By their numbers in this assay, from the lowest: compounds 3, 1, 4 and 2 (each within the scatter of the next).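

Hydroxy, on an aromatic carbon of a six-membered aromatic ring that is part of the fused system, brings a hydrogen-bond donor where nitro has none, yet in this assay the swap gives a 1.1-fold higher number from compound 3 to compound 4 (0.05 log units; within the scatter). The same spot can now be compared with two further neighbours: putting hydroxy where hydrogen stood gives a 1.1-fold higher number from compound 1 to compound 4 (0.04 log units; within the scatter), and taking the methyl off the oxygen of the methoxy group gives a 1.7-fold lower number from compound 2 to compound 4 (0.22 log units; within the scatter). Hydrogen, methoxy, nitro and hydroxy at this position therefore all count as alike in this assay, so in this set of four compounds, adding a hydrogen-bond donor here makes no difference that can be read, and the position has so far tolerated every group shown.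

Nothing shown explains why these values stay alike. Going by these compounds, whether this tolerance has a limit remains open, since only a group of a different kind at this position, such as an amine, a carboxylic acid or a longer chain, could show whether the number can move beyond the scatter.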